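The compounds below may be only part of what the source reports. "The series", "measured", "known", "first", "only" and "open" are said of these compounds alone.

Three compounds with a shared core have been examined in an ADME assay on HOS cells (Homo sapiens) for cytotoxicity; a higher number here means a weaker inhibitor, a lower number a stronger inhibitor. Compound 1 (`O=C1c2c(ccc(O)c2O)CN1Cc1ccccc1`) offers no number, its entry reading "not determined" (no result reported). Compound 2 (`O=C1c2c(ccc(O)c2O)CN1Cc1cccc(Cl)c1`) gives 9020 nM, and compound 3 (`O=C1c2c(ccc(O)c2O)CN1Cc1ccc(Cl)c(Cl)c1`) gives 5680 nM. Within the data shown here, these two values lie within the scatter of each other, so compound 2 stands level with the only other number available. Compound 4 (`O=C1c2c(ccc(O)c2O)CN1Cc1cccc(Cl)c1F`) has not yet been measured. It departs from compound 2 by a single change, (fluoro in place of hydrogen on an aromatic carbon), which places fluoro in place of hydrogen on an aromatic carbon, ortho to a chloro group. Among the measured compounds shown here, only one measured step bears on this change: a 1.6-fold lower number from compound 2 to compound 3 (0.20 log units; within the scatter). That step is of a similar kind, though the group that enters is chloro rather than fluoro, so it is a limited guide. On that single step, no shift beyond the scatter is expected in this assay. The estimated step is a 1.2-fold lower number from compound 2 to compound 4 (0.08 log units; within the scatter). Compound 4 is expected at 7500 nM, with an estimated range of 3500 nM to 16000 nM.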

Compound 4, half-maximal inhibitory concentration: 9430 nM
The estimate for compound 4 lay 1.3-fold (0.10 log units) below the measured number, within the range that was stated.
By their numbers in this assay, from the lowest: compounds 3, 2 and 4 (each within the scatter of the next).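

In this assay, fluoro in place of hydrogen on an aromatic carbon, ortho to a chloro group, gives a 1.0-fold higher number from compound 2 to compound 4 (0.02 log units; within the scatter) and so leaves the number at this position without a shift beyond the scatter. Among these compounds, the earlier step, a 1.6-fold lower number from compound 2 to compound 3 (0.20 log units; within the scatter), concerned an entering chloro group, so this is the first reading for fluoro itself, and it also stays within the scatter. Nothing available accounts for this result or attributes any property to the fluoro group.

The compounds shown leave open whether a methoxy group, an amine or a carboxylic acid at this same position would also stay within the scatter. They also leave open what fluoro does on this ring when no chloro group is present.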